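The source may hold more compounds than are shown below. What is called first, only, known or untested is meant among the compounds shown, and "the series" means these compounds.

Measured in an ADME assay on liver (Rattus norvegicus) for metabolic stability, using microsomes; a lower number here means that the compound disappears faster, a higher number that the compound lasts longer:
- Compound 1 `COc1ccc2cc1[C@H](C)CN(C)C(=O)Nc1ccc(S(=O)(=O)C3CC3)c(c1)CN(C)C(=O)C2Nc1ccc2c(N)ncc(F)c2c1`: 0.1 h
- Compound 2 `CN1Cc2cc(ccc2S(=O)(=O)C2CC2)NC(=O)CCc2cccc(c2)[C@@H](Nc2ccc3c(N)ncc(F)c3c2)C1=O`: 0.55 h
- Compound 3 `COc1cc2cc(c1)[C@@H](Nc1ccc3c(N)ncc(F)c3c1)C(=O)N(C)Cc1cc(ccc1S(=O)(=O)C1CC1)NC(=O)CC2`: 0.767 h

The values of compound 2 and compound 3 lie within the usual scatter of each other, while compound 1 gives a clearly lower number. Compound 4 `CN1Cc2cc(ccc2S(=O)(=O)C2CC2)NC(=O)CCc2cc(ccc2OCC(F)F)[C@@H](Nc2ccc3c(N)ncc(F)c3c2)C1=O` differs from compound 2 in one place: 2,2-difluoroethoxy in place of hydrogen on an aromatic carbon. Within the data shown here, one measured step bears on this change, methoxy in place of hydrogen on an aromatic carbon, and it gave a 1.4-fold higher number from compound 2 to compound 3 (0.14 log units; within the scatter). Among the measured compounds shown here, no measured compound carries 2,2-difluoroethoxy, so no change beyond the scatter is expected in this assay. The expected result is a 1.1-fold lower number from compound 2 to compound 4 (0.04 log units; within the scatter). For compound 4 the estimated value is 0.5 h, with an expected range from 0.2 h to 1.2 h.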

Compound 4, half-life: 1.07 h
For compound 4 the middle estimate is 2.1-fold (0.33 log units) below the measured one, within the range that was stated.
By their numbers in this assay, from the lowest: compound 1; then compounds 2, 3 and 4 (each within the scatter of the next).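

At the aromatic carbon ortho to a fused ring and para to a fused ring, hydrogen can give way to 2,2-difluoroethoxy, with its 5 heavy atoms, while the result in this assay stays within the scatter (a 1.9-fold higher number from compound 2 to compound 4 (0.29 log units; within the scatter)). Among these compounds, the earlier compounds held no group on this carbon and no fluorine-bearing ether, so this is the first reading for either. Nothing available explains the result.

Going by these compounds, whether an amine or a carboxylic acid on this carbon would also stay within the scatter remains open.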